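The compounds below may be only part of what the source reports. "The series", "measured", "known", "first", "only" and "open" are said of these compounds alone.

Compound 1 `O=C(O)c1ccccc1-c1ccc(CCc2ncc(Cc3ccccc3F)[nH]2)cc1` gives 177 nM in an in vitro functional assay on cells for agonist activity at Bombesin receptor subtype-3 (Homo sapiens), read by luminescence and calcium flux; on this read-out higher numbers stand for an effect only at larger amounts of compound and lower numbers for an effect already at smaller amounts. Going by the values given here, the only other number so far is that of compound 2 `O=C(O)c1ccccc1-c1ccc(CCc2ncc(CC3CCOCC3)[nH]2)cc1`, which gives 338 nM in this assay; the two values lie within the scatter of each other, the step of a 1.9-fold higher number from compound 1 to compound 2 (0.28 log units; within the scatter) being small. Compound 3 `Cc1ccc(Cc2cnc(CCc3ccc(-c4ccccc4C(=O)O)cc3)[nH]2)cc1` differs from compound 1 in one place: 4-methylphenyl in place of 2-fluorophenyl on a saturated chain carbon bound to an aromatic carbon. The step from compound 1 to compound 2 is the only one that bears on this change, and it stayed within the scatter, so nothing beyond the scatter is expected here either. Compound 3 is estimated at 200 nM, between 80 nM and 500 nM. The expected step is a 1.1-fold higher number from compound 1 to compound 3 (0.05 log units; within the scatter).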

Compound 3, half-maximal effective concentration: 2660 nM
Compound 3: middle estimate off by 13-fold (1.12 log units), on the low side; the whole stated range lies below it.
By their numbers in this assay, from the lowest: compounds 1 and 2 (each within the scatter of the next); then compound 3.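

In this assay the group on this saturated chain carbon turns out not to be indifferent: 4-methylphenyl in place of 2-fluorophenyl gives a 15-fold higher number from compound 1 to compound 3 (1.18 log units; beyond the scatter) while the oxan-4-yl change stayed within the scatter. 4-methylphenyl in place of oxan-4-yl gives a 7.9-fold higher number from compound 2 to compound 3 (0.90 log units; beyond the scatter) and so a six-membered aromatic ring of carbon only does not by itself keep the number low, since 2-fluorophenyl carries one too. No measurement at hand explains this step.

Open, on these data alone, is whether 2-methylphenyl or 4-fluorophenyl would read with compound 1 or with compound 3, and how an amine at this place would read.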